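Pyridin-2-yl for benzyl on the ring amine nitrogen

This account rests on a few compounds, and the source may have more. Where it says the series, first, only, none or still open, it means among the compounds named here.

Measured so far in a functional assay on PC-3 cells (Homo sapiens) for inhibition, with a stated time of 72 h; a higher number here means a weaker inhibitor, a lower number a stronger inhibitor:
compound 1, `O=C(Nc1ccccc1)Nc1nc(Sc2c[nH]c3ccccc23)cc(N2CCCC2)n1`, gives 14900 nM
compound 2, `O=C(Nc1ccccc1)Nc1nc(Sc2c[nH]c3ccccc23)cc(N2CCN(Cc3ccccc3)CC2)n1`, gives 42500 nM
compound 3, `Cc1ccc(C)c(NC(=O)Nc2nc(Sc3c[nH]c4ccccc34)cc(N3CCN(Cc4ccccc4)CC3)n2)c1`, gives 17300 nM

For the measured compounds named here, compound 2 holds the highest of the three numbers in this assay; compound 3 lies nearest, a step of a 2.5-fold lower number from compound 2 to compound 3 (0.39 log units; beyond the scatter), and compound 1 lies furthest, with its own value shown above but with no single-point step to compound 2 to quote.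

Compound 4, `O=C(Nc1ccccc1)Nc1nc(Sc2c[nH]c3ccccc23)cc(N2CCN(c3ccccn3)CC2)n1`, is not yet measured. Relative to compound 2 the change is pyridin-2-yl in place of benzyl on an amine nitrogen in a ring.

Going by the values given here, the only step measured is a 2.5-fold lower number from compound 2 to compound 3 (0.39 log units; beyond the scatter), and it sits on the amide-type nitrogen, not on the ring amine nitrogen that is changed here. Among the compounds with values here, no measured step touches the group on that ring nitrogen, so nothing speaks directly to the size or direction of the change from compound 2 to compound 4 in this assay. Within the data shown here, with no bearing step, the expectation is no change beyond the scatter, a step of a 1.4-fold lower number from compound 2 to compound 4 (0.15 log units; within the scatter) at most. Compound 4 is therefore estimated at 30000 nM, within a range from 8000 nM to 120000 nM.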

Compound 4, half-maximal inhibitory concentration: 21600 nM
Compound 4: the middle estimate sits 1.4-fold (0.14 log units) above what was measured; measured number inside the range.
By their numbers in this assay, from the lowest: compounds 1, 3, 4 and 2 (each within the scatter of the next, the first and the last beyond it).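

In this assay, the first change measured on the ring amine nitrogen, pyridin-2-yl in place of benzyl, gives a 2.0-fold lower number from compound 2 to compound 4 (0.29 log units; within the scatter) and so stays inside the usual spread of repeats, even though the entering ring brings a hydrogen-bond acceptor that the benzyl lacks. A larger exchange on the aromatic carbon of the shared core, 4-(pyridin-2-yl)piperazin-1-yl in place of pyrrolidin-1-yl, gives a 1.4-fold higher number from compound 1 to compound 4 (0.16 log units; within the scatter) and is likewise within the scatter, so that pair cannot be told apart in this cell assay. Nothing outside these cell numbers bears on the result, and no explanation can be offered for it.

Still open, on these data alone, is how a smaller or differently built group on the ring nitrogen, such as a methyl, an acetyl or a pyridin-4-yl, would read in this assay against the benzyl and pyridin-2-yl pair. Also open, as far as these compounds go, is whether the 2,5-dimethylphenyl change on the amide-type nitrogen, seen as a 2.5-fold lower number from compound 2 to compound 3 (0.39 log units; beyond the scatter) with benzyl on the ring nitrogen, would hold with pyridin-2-yl there.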